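A few compounds are considered here, and "the series" means these few. Any claim that something is new, unique, unknown or untested is made for them only; others in the source may bear on it.

In an ADME assay for permeability, using PAMPA, at pH 7.4 (on this read-out higher numbers stand for higher permeability and lower numbers for lower permeability), compound 1 `Cc1cc(NC(=O)Nc2ccc(N(C)C)cc2)c2ccccc2n1` gives 2 10^-6 cm/s. Compound 2 `Cc1cc(NC(=O)Nc2ccc(SC(F)(F)F)cc2)c2ccccc2n1` gives 206 10^-6 cm/s, and compound 3 `Cc1cc(NC(=O)Nc2ccc(OC(F)(F)F)cc2)c2ccccc2n1` gives 531 10^-6 cm/s, the highest of the three numbers, with compound 2 nearest and compound 1 furthest. The steps of a 100-fold higher number from compound 1 to compound 2 (2.01 log units; beyond the scatter) and a 270-fold higher number from compound 1 to compound 3 (2.42 log units; beyond the scatter) were both large, whereas the step of a 2.6-fold higher number from compound 2 to compound 3 (0.41 log units; beyond the scatter) was modest. Compound 4 `Cc1cc(NC(=O)Nc2ccc(C(F)(F)F)cc2)c2ccccc2n1` has not yet been measured in this assay; it differs from compound 3 by trifluoromethyl in place of trifluoromethoxy on an aromatic carbon. For the measured compounds named here, no measured step covers this exact exchange, and the nearest comparison among the measured compounds is the modest step of a 2.6-fold higher number from compound 2 to compound 3 (0.41 log units; beyond the scatter). On that basis the expected step is a modest one downward, or none beyond the scatter: a 1.5-fold lower number from compound 3 to compound 4 (0.18 log units; within the scatter). Compound 4 is therefore estimated at 350 10^-6 cm/s, within 150 10^-6 cm/s to 800 10^-6 cm/s.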

Compound 4, apparent permeability: 2 10^-6 cm/s
Compound 4: middle estimate off by 180-fold (2.24 log units), on the high side, and the stated range ends above it.
By their numbers in this assay, from the lowest: compounds 1 and 4 (each within the scatter of the next); then compound 2; then compound 3.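

In this assay, the fluorinated groups at this position do not behave as one class: trifluoromethyl in place of trifluoromethoxy gives a 270-fold lower number from compound 3 to compound 4 (2.42 log units; beyond the scatter), and trifluoromethyl in place of (trifluoromethyl)sulfanyl gives a 100-fold lower number from compound 2 to compound 4 (2.01 log units; beyond the scatter). Trifluoromethyl in place of dimethylamino gives no change at the digits printed from compound 1 to compound 4 (within the scatter), so fluorine in the group does not by itself separate the high numbers from the low numbers in these compounds. Nothing available accounts for this split.

Going by these compounds, whether a methoxy group, a chlorine or a pentafluoroethyl chain at this position would group with compound 4 or with compound 3 remains open.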